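A few compounds are considered here, and "the series" means these few. Any claim that something is new, unique, unknown or untested is made for them only; others in the source may bear on it.

Measured compounds:
compound 2 `Cc1c(OCCCCOc2cccc(C(=O)O)c2)ccc(C(=O)CC2CCCC2)c1O` gives 80.6%
compound 1 `COC(=O)c1ccc(OCCCCOc2ccc(C(=O)CC3CCCC3)c(C)c2C)cc1` gives 14.1%

In an assay on HEK293 cells for positive allosteric modulation of metabotropic glutamate receptor 2 (Rattus norvegicus), read by thallium flux, with a stated time of 2.5 min (on this read-out higher numbers stand for larger maximal responses and lower numbers for smaller maximal responses), compound 2 holds the highest of the two numbers. For the measured compounds named here, its only neighbour is compound 1, whose value in this assay lies well below it, a gap beyond the usual scatter. Going by the values given here, the two compounds differ in more than one place, so the numbers say only that the pair differ widely, not which part of the structure carries the difference.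

Compound 3 `Cc1c(OCCCCOc2cccc(C(=O)O)c2)ccc(C(=O)CC2CCCC2)c1C` is not yet measured. It departs from compound 2 in a single place: methyl in place of hydroxy on an aromatic carbon. Compound 1 carries a methyl group at the same place, and its value in this assay is low, while compound 2 with the hydroxy group sits high. Compound 3 shares the methyl of compound 1 and the remainder of compound 2, so the account expects a step downward from compound 2 in this assay, large rather than small, though the other difference between compound 1 and compound 2 leaves its size uncertain. The expected step is a number 35.6 percentage points lower from compound 2 to compound 3 (beyond the scatter). For compound 3 the estimate in this assay is 45%, with a range from 12% to 80%.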

Compound 3, largest response reached (reported as percent of maximum), in percent of the reference or control that the assay uses: 22.4%
Compound 3: the middle estimate sits 22.6 percentage points above what was measured; low and high end bracket the measured number.
By their numbers in this assay, from the lowest: compounds 1 and 3 (each within the scatter of the next); then compound 2.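

In this assay, the exchange of hydroxy for methyl on the aromatic carbon ortho to the (cyclopentylmethyl)carbonyl group is, on its own, enough to produce a large drop, with a number 58.2 percentage points lower from compound 2 to compound 3 (beyond the scatter) and the rest of the structure unchanged, a single-place effect that the earlier pair could not isolate from their other difference. The exchange of 3-carboxyphenyl for 4-(methoxycarbonyl)phenyl on the oxygen gives a number 8.3 percentage points higher from compound 1 to compound 3 (within the scatter), so with the methyl group in place these two end groups cannot be told apart in this assay. Nothing available here explains why this one exchange has so large an effect.

The compounds shown do not tell whether a methoxy group, an amine or a fluorine on this aromatic carbon would keep the response seen with the hydroxy group. They also leave open whether the 4-(methoxycarbonyl)phenyl group would match the 3-carboxyphenyl group with the hydroxy group present, and how a longer chain between the two oxygens would fare.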